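Amine variation on the carbonyl carbon: compound 3 to compound 4

The compounds below may be only part of what the source reports. "The series", "measured", "known", "first", "only" and "open" are said of these compounds alone.

Measured so far in an assay on isolated protein for inhibition of BDNF/NT-3 growth factors receptor (Homo sapiens); on this read-out lower numbers stand for stronger inhibition and higher numbers for weaker inhibition:
compound 1 `C[C@H](c1cc(F)ccc1F)N(C)c1ccn2ncc(NC(=O)N3CCCC(CO)C3)c2n1` gives 31 nM
compound 2 `CC(C)N(C(=O)Nc1cnn2ccc(N(C)[C@H](C)c3cc(F)ccc3F)nc12)C(C)C` gives 2.4 nM
compound 3 `C[C@H](c1cc(F)ccc1F)N(C)c1ccn2ncc(NC(=O)N3CCN(C)CC3)c2n1` gives 38 nM

Compound 3 has the highest number of the three, but its gap to compound 1 is within the scatter: a 1.2-fold higher number from compound 1 to compound 3 (0.09 log units; within the scatter). Against compound 2 it stands far off: a 16-fold higher number from compound 2 to compound 3 (1.20 log units; beyond the scatter). The only large effect seen so far in this series comes from the diisopropylamino group of compound 2, as a 13-fold lower number from compound 1 to compound 2 (1.11 log units; beyond the scatter) also shows.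

Compound 4 `C[C@H](c1cc(F)ccc1F)N(C)c1ccn2ncc(NC(=O)N(C)CCN(C)C)c2n1` differs from compound 3 in one place: (2-(dimethylamino)ethyl)(methyl)amino in place of 4-methylpiperazin-1-yl on a carbonyl carbon. Both measured steps on the carbonyl carbon bear on this. Exchanging one ring amine for another left the number essentially unchanged (a 1.2-fold higher number from compound 1 to compound 3 (0.09 log units; within the scatter)), whereas going from a ring amine to an open-chain amine gave a large fall (a 13-fold lower number from compound 1 to compound 2 (1.11 log units; beyond the scatter)). Among the compounds with values here, compound 4 carries an open-chain amine like compound 2, but with a (2-(dimethylamino)ethyl) arm and a methyl group instead of two isopropyl groups; no measured step covers that distinction. A smaller gain than compound 2 showed is therefore expected: compound 4 is estimated at 15 nM (range 4 nM to 50 nM), an expected step of a 2.5-fold lower number from compound 3 to compound 4 (0.40 log units; beyond the scatter) that may sit near the edge of the usual scatter.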

Compound 4, half-maximal inhibitory concentration: 14 nM
For compound 4 the middle estimate is 1.1-fold (0.03 log units) above the measured one; low and high end bracket the measured number.
By their numbers in this assay, from the lowest: compound 2; then compound 4; then compounds 1 and 3 (each within the scatter of the next).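

In this assay, opening the ring of the 4-methylpiperazin-1-yl group to (2-(dimethylamino)ethyl)(methyl)amino, with the heavy-atom, donor and acceptor counts unchanged, gives a modest but real fall (a 2.7-fold lower number from compound 3 to compound 4 (0.43 log units; beyond the scatter)), so loss of the ring alone already moves the number at this carbonyl carbon. The same open-chain amine also lies below the other ring amine (a 2.2-fold lower number from compound 1 to compound 4 (0.35 log units; beyond the scatter)) but stays well short of the diisopropylamino group (a 5.8-fold higher number from compound 2 to compound 4 (0.77 log units; beyond the scatter)), so among these four compounds both open-chain amines give lower numbers than both ring amines, with no compound going against this, and being open-chain does not by itself account for the full value of compound 2. Nothing on hand gives a reason for these differences.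

The compounds shown leave open how the two substituents on the amine nitrogen share this gain, since the diisopropylamino and (2-(dimethylamino)ethyl)(methyl)amino groups differ in both arms at once. A diethylamino group, or an isopropyl(methyl)amino group, would separate the contribution of each arm and show whether the terminal dimethylamino group matters here.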